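The source may report more compounds than this note shows. Statements on the series, on what has been measured and on what is new or still open speak of the compounds shown alone.

Measured in a functional assay on A2780 cells (Homo sapiens) for antiproliferative activity, read by sulforhodamine B assay, with a stated time of 72 h; on this read-out lower numbers stand for stronger inhibition and higher numbers for weaker inhibition:
- compound 1 `O=C(NCc1ccc(S(=O)(=O)c2cc(F)cc(F)c2)cc1)c1cc2ccncc2o1`: 9 nM
- compound 2 `O=C(NCc1ccc(S(=O)(=O)C2CCOCC2)cc1)c1cc2ccncc2o1`: 87 nM

Compound 2, at 87 nM, holds the higher of the two numbers and is the weaker of the pair. Next is compound 3 `CC(C)N1CCC(S(=O)(=O)c2ccc(CNC(=O)c3cc4ccncc4o3)cc2)CC1`, which differs from compound 2 as follows: 1-isopropylpiperidin-4-yl in place of oxan-4-yl on a sulfonyl sulfur. In words, 1-isopropylpiperidin-4-yl stands in place of oxan-4-yl on a sulfonyl sulfur. Among the compounds with values here, the only measured step at that sulfur is a 9.7-fold higher number from compound 1 to compound 2 (0.99 log units; beyond the scatter). It involved a different exchange, with oxan-4-yl in place of 3,5-difluorophenyl, so it shows that this place matters but gives no direction for the new change. The leaving and entering groups are each one six-membered non-aromatic ring with 1 hetero atom, so no step beyond the scatter is expected in this assay, though a step as large as the measured one cannot be excluded. The estimated step is a 1.1-fold lower number from compound 2 to compound 3 (0.04 log units; within the scatter). For compound 3 the expected value is 80 nM, with an estimated range of 20 nM to 300 nM.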

Compound 3, half-maximal inhibitory concentration: 52 nM
Beside the measured number, compound 3's estimate is 1.5-fold (0.19 log units) above it; the range from low to high includes it.
By their numbers in this assay, from the lowest: compound 1; then compounds 3 and 2 (each within the scatter of the next).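

In this assay, within the data shown here, 1-isopropylpiperidin-4-yl in place of oxan-4-yl on the sulfonyl sulfur gives a 1.7-fold lower number from compound 2 to compound 3 (0.22 log units; within the scatter) and so is the first exchange at this place that stays within the scatter, even though the entering group is the larger of the two. Set against the 3,5-difluorophenyl group, the same 1-isopropylpiperidin-4-yl group gives a 5.8-fold higher number from compound 1 to compound 3 (0.76 log units; beyond the scatter) in this series, so compound 1 keeps the lowest number of the three. Nothing at hand gives a reason for either step.

Open, from the compounds shown here alone, is whether a piperidin-4-yl with a free ring amine or a 1-acetylpiperidin-4-yl would stay close to compound 2 and compound 3 or move toward compound 1. Also open, going by these compounds, is whether a plain phenyl group or a 3-fluorophenyl group would hold the number of compound 1.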